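The compounds below may be only part of what the source reports. "The series", "measured", "known", "first", "only" and "open" are said of these compounds alone.

Three measured compounds share one core and differ only in the group carried on an aromatic carbon of the fused ring system. Compound 1 `COc1ccc(F)cc1CNCCCNc1ccnc2cc(-c3ccc(F)cc3)ccc12` gives 9.47 in a physicochemical assay for acid dissociation. Compound 2 `COc1ccc(F)cc1CNCCCNc1ccnc2cc(-c3ccccc3)ccc12` gives 9.47, and compound 3 `COc1ccc(F)cc1CNCCCNc1ccnc2cc(Cc3ccccc3)ccc12` gives 9.47. The step of no change at the digits printed from compound 1 to compound 2 (within the scatter) and the step of no change at the digits printed from compound 2 to compound 3 (within the scatter) both show that swapping the group on that aromatic carbon left the read-out untouched, and the step of no change at the digits printed from compound 1 to compound 3 (within the scatter) says the same. Compound 3 therefore stands level with compound 1 and compound 2 at the digits shown, and no one of the three can be set apart from the others.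

Compound 4 `COc1ccc(-c2ccc3c(NCCCNCc4cc(F)ccc4OC)ccnc3c2)cc1` is not yet measured. It differs from compound 3 in this way: 4-methoxyphenyl in place of benzyl on an aromatic carbon. The three measured steps all concern the same position and each was flat, so the change from compound 3 to compound 4 is expected to bring no step beyond the scatter in this assay; the expected step is no change at the digits printed from compound 3 to compound 4 (within the scatter). The value of compound 4 in this assay is therefore estimated at 9.47, with a range from 9.2 to 9.75.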

Compound 4, acid dissociation constant: 9.47
The estimate for compound 4 equals the measured number at the digits printed; measured number inside the range.
By their numbers in this assay, from the lowest: compounds 1, 2, 3 and 4 (each within the scatter of the next).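

In this assay, going by these compounds alone, the exchange of benzyl for 4-methoxyphenyl, which brings an oxygen and 1 hydrogen-bond acceptor to a place where the group leaving has 0, gave no change at the digits printed from compound 3 to compound 4 (within the scatter) and is the first change here to put such an atom on this aromatic carbon. The methoxy group, read directly against hydrogen and against fluoro on the same outer ring, gave no change at the digits printed from compound 2 to compound 4 (within the scatter) and no change at the digits printed from compound 1 to compound 4 (within the scatter), so the flat read-out in this assay now extends to a group with an oxygen as well as to the hydrogen, fluoro and benzyl variants. Nothing available explains why the read-out stays level across these four compounds.

On these data alone, all four compounds carry a six-membered aromatic ring of carbon only with no net charge at this place, so it remains open whether the read-out would stay level with an amine, a carboxylic acid or a longer chain there. The compounds shown also share everything outside this position, which leaves open how this assay would respond to a change elsewhere in the shared core or its side chain.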